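The source may report more compounds than this note shows. Statements on the series, on what has been measured and on what is new or still open speak of the compounds shown alone.

Working notes on the series. Compound 1 `O=C(O)CCc1ccc(NCc2cccc(Br)c2)cc1` gives 120% in a functional assay on CHO cells for agonist activity at Free fatty acid receptor 1 (Homo sapiens), read by reporter gene assay; a lower number here means a smaller maximal response, a higher number a larger maximal response. Compound 2 `O=C(O)CCc1ccc(NCc2cccc(F)c2)cc1` gives 120% in this assay, and the step of no change at the digits printed from compound 1 to compound 2 (within the scatter) shows fluoro in place of bromo on an aromatic carbon leaves the maximal response unchanged within the scatter. Going by the values given here, compound 3 `COc1ccc(CNc2ccc(CCC(=O)O)cc2)cc1` gives 159% in this assay, a number beyond the scatter above compound 2; no single-point step connects it to compound 2. Compound 2 thus stands level with compound 1 at the low end of the three numbers.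

The next compound, compound 4 `NC(=O)c1cccc(CNc2ccc(CCC(=O)O)cc2)c1`, differs from compound 2 by carbamoyl in place of fluoro on an aromatic carbon. Among the compounds with values here, the only measured step at this position, from compound 1 to compound 2, swapped one halogen for another and produced nothing beyond the scatter; no measured step brings in a carbamoyl or any hydrogen-bond donor or acceptor at this place, so the bearing of that step is limited. The expectation is therefore a step of no change at the digits printed from compound 2 to compound 4 (within the scatter), with wide uncertainty. Compound 4 is estimated at 120% in this assay, within 90% to 155%.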

Compound 4, largest response reached (reported as percent of maximum), in percent of the reference or control that the assay uses: 18%
Estimate against measurement, compound 4: 102 percentage points above; the measured number lies below the stated range.
By their numbers in this assay, from the lowest: compound 4; then compounds 1 and 2 (each within the scatter of the next); then compound 3.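

This position is not indifferent to what it carries. The two halogens could not be told apart in this assay, yet carbamoyl in place of fluoro gives a number 102 percentage points lower from compound 2 to compound 4 (beyond the scatter) and carbamoyl in place of bromo gives a number 102 percentage points lower from compound 1 to compound 4 (beyond the scatter), so the maximal response can change sharply with the group placed here, which the halogen swap gave no sign of. Nothing measured in this series offers an explanation for the fall.

On these data alone, whether the fall follows the whole carbamoyl or only a part of it stays open, and a nitrile or a methyl ester at this place would bear on that. As far as these compounds go, how a carboxylic acid or an amine on the same aromatic carbon would compare also remains open.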